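The source may report more compounds than this note shows. Statements on the series, on what has been measured and on what is new or still open speak of the compounds shown alone.

Among the compounds with values here, compound 1 `O=C(Nc1ccc(F)cc1)C1(c2ccc3c(n2)CCN3c2ccccn2)CCC1` is tested in an assay on HeLa cells for inhibition of Indoleamine 2,3-dioxygenase 1 (Homo sapiens) (on this read-out higher numbers stand for weaker inhibition and lower numbers for stronger inhibition), where compound 1 gives 10.9 nM, the highest of the three numbers so far. Within the data shown here, compound 2 `Cc1nccc(N2CCc3cc(C4(C(=O)Nc5ccc(F)cc5)CCC4)ccc32)n1` gives 5.2 nM, and compound 3 `O=C(Nc1ccc(Cl)cc1)C1(c2ccc3c(n2)CCN3c2ccccn2)CCC1` gives 2.3 nM; the only single-place step measured, a 4.7-fold lower number from compound 1 to compound 3 (0.68 log units; beyond the scatter), concerns the ring carrying the halogen and not the nitrogen changed here. Compound 4 `O=C(OC1CC1)N1CCc2nc(C3(C(=O)Nc4ccc(F)cc4)CCC3)ccc21` differs from compound 1 as follows: cyclopropyloxycarbonyl in place of pyridin-2-yl on a nitrogen on an aromatic ring in a ring. Among the measured compounds shown here, compound 2 also differs from compound 1 on a nitrogen on an aromatic ring in a ring, and its number is lower, but no measured step bears directly on this exchange, so the expectation is uncertain and is set as a small step, a 1.8-fold higher number from compound 1 to compound 4 (0.26 log units; within the scatter). Compound 4 is therefore expected to give about 20 nM, within 5 nM to 80 nM.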

Compound 4, half-maximal inhibitory concentration: 2.7 nM
Compound 4: the middle estimate sits 7.4-fold (0.87 log units) above what was measured, and the stated range ends above it.
By their numbers in this assay, from the lowest: compounds 3, 4 and 2 (each within the scatter of the next, the first and the last beyond it); then compound 1.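

The nitrogen of the shared core does not need an aromatic ring on it to give a low number: with cyclopropyloxycarbonyl in place of pyridin-2-yl, the step is a 4.0-fold lower number from compound 1 to compound 4 (0.61 log units; beyond the scatter). A non-aromatic group holding a carbonyl and a three-membered ring of carbon only is therefore tolerated at this position. Nothing available explains this drop in the number.

From the compounds shown here alone, whether the cyclopropyl ring itself matters stays open, and an ethoxycarbonyl or acetyl group on this nitrogen would test that. Also open, going by these compounds, is whether chloro in place of fluoro would lower the number further on compound 4.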